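A few compounds are considered here, and "the series" means these few. Any claim that something is new, unique, unknown or untested is made for them only; others in the source may bear on it.

Compound 3 `CNC(=O)CCc1ccncc1-c1ccc2ccccc2c1` shares its core with compound 1 `NNC(=O)COc1ccncc1-c1ccc2ccccc2c1`, compound 2 `O=C(O)/C=C/c1ccncc1-c1ccc2ccccc2c1` and compound 4 `CN(C)C(=O)/C=C/c1ccncc1-c1ccc2ccccc2c1`. In an assay on a protein complex for inhibition of CDK8/Cyclin C (Homo sapiens), with a stated time of 1 h (a lower number here means a stronger inhibitor, a higher number a weaker inhibitor), compound 2 gives 5 nM, and compound 3 gives 21.1 nM, the higher of the two numbers that exist; for compound 1 the entry is "not determined" (no result reported). Among the measured compounds shown here, the only measured step, a 4.2-fold higher number from compound 2 to compound 3 (0.63 log units; beyond the scatter), replaced the 2-carboxyethenyl group of compound 2 with a saturated methylamide chain. The change now considered is 2-(dimethylcarbamoyl)ethenyl in place of 2-(methylcarbamoyl)ethyl on an aromatic carbon, which brings back a double bond in the chain while keeping an amide. That step bears on it only in part: compound 2 carries an acid and compound 4 does not. A number between the two measured ones is expected for compound 4, about 14 nM, with a range from 4 nM to 50 nM, meaning an estimated 1.5-fold lower number from compound 3 to compound 4 (0.18 log units; within the scatter).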

Compound 4, half-maximal inhibitory concentration: 30.1 nM
Compound 4: middle estimate off by 2.2-fold (0.33 log units), on the low side, and the stated range covers the measured number.
By their numbers in this assay, from the lowest: compound 2; then compounds 3 and 4 (each within the scatter of the next).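

In this assay, a 1.4-fold higher number from compound 3 to compound 4 (0.15 log units; within the scatter), so the two amides cannot be told apart, even though 2-(dimethylcarbamoyl)ethenyl has no amide hydrogen and brings back the double bond. With the double bond kept, dimethylamino in place of hydroxy on the carbonyl carbon gives a 6.0-fold higher number from compound 2 to compound 4 (0.78 log units; beyond the scatter), which separates the carboxylic acid of compound 2 from this amide. No measured evidence accounts for either result. Still open, going by these compounds, is how a primary amide, an amine or a longer chain at this position would compare with the carboxylic acid.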